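A few compounds are considered here, and "the series" means these few. Any claim that something is new, unique, unknown or untested is made for them only; others in the source may bear on it.

Measured compounds:
compound 1, `COc1cc(-c2cc(/C=C/C(=O)c3ccc(N)cc3)[nH]n2)cc(OC)c1OC`: 108%
compound 2, `COc1ccc(C(=O)/C=C/c2cc(-c3cc(OC)c(OC)c(OC)c3)n[nH]2)cc1OC`: 93%
compound 3, `COc1ccc(C(=O)/C=C/c2cc(-c3cc(OC)c(OC)c(OC)c3)n[nH]2)cc1`: 101%

All three were tested in a functional assay on HCC 2998 cells (Homo sapiens) for cytotoxicity, read by sulforhodamine B assay, with a stated time of 48 h, tested at 0.01 uM; a lower number here means a stronger effect, a higher number a weaker effect of the compound at the concentration tested. Compound 2 is set apart only from compound 1, by a number 15 percentage points lower from compound 1 to compound 2 (beyond the scatter); against compound 3 the gap is a number 8 percentage points higher from compound 2 to compound 3 (within the scatter), so those two cannot be told apart on these numbers. The three compounds share a core and differ only in the groups on the ring attached to the carbonyl.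

The compound now in question is compound 4, `COc1cc(C(=O)/C=C/c2cc(-c3cc(OC)c(OC)c(OC)c3)n[nH]2)cc(OC)c1OC`. It differs from compound 2 by methoxy in place of hydrogen on an aromatic carbon. Among the measured compounds shown here, one measured step touches this kind of change: from compound 2 to compound 3 a methoxy group on an aromatic carbon was replaced by hydrogen, and the result was a number 8 percentage points higher from compound 2 to compound 3 (within the scatter), a change too small to count. The step to compound 4 runs the other way, adding a methoxy group rather than removing one, and nothing seen so far suggests that adding one would move the read-out noticeably. The expectation for this assay is therefore a step of no more than the usual scatter, in no clear direction.

The value of compound 4 is estimated at 90%, with a likely range from 76% to 104%, which means an expected step of a number 3 percentage points lower from compound 2 to compound 4 (within the scatter).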

Compound 4, a percentage reported as activity, at one concentration (the size of the read-out at that concentration, not a potency): 102%
For compound 4 the middle estimate is 12 percentage points below the measured one, and the stated range covers the measured number.
By their numbers in this assay, from the lowest: compounds 2, 3, 4 and 1 (each within the scatter of the next, the first and the last beyond it).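

Putting a methoxy group in place of hydrogen on the ring attached to the carbonyl, at a carbon ortho to a methoxy group and meta to a large group, gives in this assay a number 9 percentage points higher from compound 2 to compound 4 (within the scatter). Among the compounds shown here, until now the only methoxy change on compound 2 was a removal, with a number 8 percentage points higher from compound 2 to compound 3 (within the scatter), so this result adds the opposite case: at this concentration, neither taking one methoxy group away from compound 2 nor adding one gives a step larger than the usual scatter of the read-out. There is no measurement here that could explain why this ring tolerates the extra methoxy group so quietly, and the result is recorded only as an observation.

On these data alone, whether a hydroxyl group, a fluorine atom or a longer chain such as ethoxy at this same carbon would behave like methoxy remains open. Also open, as far as these compounds go, is whether these compounds would separate at a higher concentration, since a single low concentration shows the size of a read-out and not a potency.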